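Chloro substitution on the aromatic ring of the tert-butyl ester oxindole

This account rests on a few compounds, and the source may have more. Where it says the series, first, only, none or still open, it means among the compounds named here.

The series is described in a toxicity assay on L02 cells (Homo sapiens) for inhibition, read by CCK-8 assay, with a stated time of 72 h, tested at 20 uM; on this read-out higher numbers stand for more inhibition of growth at the one concentration tested and lower numbers for less inhibition of growth. Compound 1 `CC(C)(C)OC(=O)/C=C1/C(=O)Nc2ccccc21` gives 64.1%, the highest of the three numbers shown, though its distance to each of the others is within the scatter. Compound 2 `CC(C)(C)OC(=O)/C=C1/C(=O)N(Cc2ccccc2)c2ccccc21` gives 62%, and compound 3 `COc1ccc2c(c1)NC(=O)/C2=C/C(=O)OC(C)(C)C` gives 63.6%. The step of a number 2.1 percentage points lower from compound 1 to compound 2 (within the scatter) and the step of a number 0.5 percentage points lower from compound 1 to compound 3 (within the scatter) both stay within the scatter, so neither substitution on the shared core of compound 1 shifted the read-out.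

Compound 4 `CC(C)(C)OC(=O)/C=C1/C(=O)Nc2c(Cl)cccc21` differs from compound 1 by chloro in place of hydrogen on an aromatic carbon, placed on an aromatic carbon of a six-membered aromatic ring of carbon only, part of a fused system of two rings, ortho to a fused ring and meta to a fused ring. The two measured steps bear on it as substitutions of the same core: both were within the scatter. The expectation for compound 4 is therefore a step of a number 1.1 percentage points lower from compound 1 to compound 4 (within the scatter), not beyond the scatter. Compound 4 is estimated at 63%, with a range from 50% to 75%.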

Compound 4, percent growth inhibition at one concentration: 64%
The estimate for compound 4 lay 1 percentage points below the measured number, and the stated range covers the measured number.
By their numbers in this assay, from the lowest: compounds 2, 3, 4 and 1 (each within the scatter of the next).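

In this assay, chloro in place of hydrogen on an aromatic carbon, ortho to a fused ring and meta to a fused ring, gives a number 0.1 percentage points lower from compound 1 to compound 4 (within the scatter), so a halogen at this position leaves the read-out where it was. Compound 4 thus adds a second group on an aromatic carbon of the shared core, after the methoxy of compound 3, for which the step was a number 0.5 percentage points lower from compound 1 to compound 3 (within the scatter).

The compounds shown leave open whether an amine or a carboxylic acid on this same aromatic carbon would also stay within the scatter. They also leave open what chloro would do on the other aromatic carbons of the ring, or a longer chain in place of the tert-butyl group of the ester. Nothing given here offers an explanation for the chloro result.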